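A few compounds are considered here, and "the series" means these few. Any claim that something is new, unique, unknown or untested is made for them only; others in the source may bear on it.

Three measured compounds share one core. Compound 1 `CC(C)n1ccc2c(C(=O)Nc3ccc(F)cc3)cc(-c3cccs3)nc21`, compound 2 `CC(C)n1ncc2c(C(=O)Nc3cccnc3)cc(-c3cccs3)nc21` and compound 3 `CC(C)n1ncc2c(C(=O)Nc3ccc(F)c(F)c3)cc(-c3cccs3)nc21` were tested in an ADME assay on LLC-MK2 cells (Macaca mulatta) for cytotoxicity, read by spectrophotometry and crystal violet staining, with a stated time of 4 days; on this read-out higher numbers stand for lower toxicity in this test and lower numbers for higher toxicity in this test. In this assay compound 1 gives > 200000 nM, a limit of the assay rather than a number. In this assay compound 2 gives > 200000 nM, again a limit. Compound 3 reaches > 200000 nM in this assay, also a limit. The step that the two limits leave unreadable from compound 2 to compound 3 therefore cannot be read, as both of its ends sit at the limit of > 200000 nM in this assay, at which 3 of the 3 values shown sit. Compound 4 `CC(C)n1ncc2c(C(=O)Nc3cccc(C(N)=O)c3)cc(-c3cccs3)nc21` has not been measured. It differs from compound 2 by 3-carbamoylphenyl in place of pyridin-3-yl on an amide-type nitrogen. Among the measured compounds shown here, the only measured step that touches the same position, the step from compound 2 to compound 3, has no readable size, so no size can be taken from it, and every value shown sits at the limit. Compound 4 is therefore expected to stay at the limit as well, with an expected step of a number no higher from compound 2 to compound 4 (the limit leaves the size open) in this assay. The estimated value for compound 4 is 200000 nM, in the expected range from 100000 nM to 400000 nM.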

Compound 4, half-maximal cytotoxic concentration: 25000 nM
For compound 4 the middle estimate is 8.0-fold (0.90 log units) above the measured one; the whole stated range lies above it.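

In this assay, 3-carbamoylphenyl on the amide-type nitrogen gives an at least 8.0-fold lower number from compound 2 to compound 4 (0.90 log units; beyond the scatter) and, set against 3,4-difluorophenyl, an at least 8.0-fold lower number from compound 3 to compound 4 (0.90 log units; beyond the scatter) in this test. The group at this position can therefore shift the read-out towards higher toxicity in this test, which the earlier step between pyridin-3-yl and 3,4-difluorophenyl could not show, as that step cannot be read. Among the compounds shown here, compound 4 is the only compound to fall below the value shared by the others, which is a limit and not a number: the limit of > 200000 nM in this assay, at which 3 of the 4 values shown sit.

The compounds shown leave open whether this shift needs the carbamoyl group itself, which a carboxylic acid or a nitrile in its place on the phenyl ring would test. They also leave open whether the same change would act alike on the core of compound 1.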